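The source may hold more compounds than are shown below. What is called first, only, known or untested is meant among the compounds shown, and "the series" means these compounds.

Compound 1 `Cc1cccc(N2CCN(C(=O)CN3C(=O)CC(C)(c4ccccc4)C3=O)CC2)c1` and compound 2 `CC1(c2ccccc2)CC(=O)N(CC(=O)N2CCN(c3ccccc3F)CC2)C1=O` share a core and differ in the aryl group on the piperazine nitrogen. In a functional assay on the whole organism (strain CD-1) with Mus musculus as the target, with a stated time of 0.5 h (a higher number here means that more compound is needed for the effect, a lower number that less compound is needed), compound 1 gives "not active" (no number reported), which is a verdict rather than a number. In this assay, compound 2 gives 100 mg/kg; this is the only number shown, and compound 2 therefore stands alone as the single measured dose, with compound 1 contributing no figure to compare against. Compound 3 `CC1(c2ccccc2)CC(=O)N(CC(=O)N2CCN(c3ccc(Cl)c(Cl)c3)CC2)C1=O` is not yet measured. It differs from compound 2 in one place: 3,4-dichlorophenyl in place of 2-fluorophenyl on an amine nitrogen in a ring. Among the measured compounds shown here, no measured step is available to guide the size of this change, so the expectation is for a step in this assay of no more than the usual scatter, in either direction. Compound 3 is expected to give 100 mg/kg in this assay, within a range from 30 mg/kg to 300 mg/kg, which means an expected step of no change at the digits printed from compound 2 to compound 3 (within the scatter).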

Compound 3, minimum effective dose: "not active" (no number reported)
Nothing numeric was reported for compound 3; no gap can be computed for the estimate.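

In this assay, among the compounds shown here, compound 3 carries a verdict and no number, and so no step from compound 2 to compound 3 can be read. Nothing shown accounts for this result. On these data alone, how the aryl group on the ring nitrogen affects the dose needed remains open, with compound 2 alone holding a number.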